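The source may hold more compounds than are shown below. What is called first, only, known or untested is meant among the compounds shown, and "the series" means these compounds.

Measured so far:
compound 1, `CC(C)(C)c1ccc(CN(Cc2cccc(CCC(=O)O)c2)S(=O)(=O)c2ccc(Cl)cc2)cc1`: > 3200 nM
compound 2, `CCCCCC(O)CCCN(CCCCC(=O)O)S(C)(=O)=O`: > 3200 nM

In an assay on HEK293 cells for inhibition of prostaglandin E2 receptor EP2 subtype (Rattus norvegicus) (on this read-out lower numbers stand for stronger inhibition and higher numbers for weaker inhibition), compound 1 returns only a limit, > 3200 nM. Compound 2 likewise returns only a limit, > 3200 nM. Both values sit at the limit of > 3200 nM in this assay, at which 2 of the 2 values shown sit, so compound 2 stands nowhere distinct among the numbers shown. Compound 3, `CCCCCC(O)CCCN(CCCCCC(=O)O)S(C)(=O)=O`, differs from compound 2 by carboxymethyl in place of carboxy on a saturated chain carbon, four bonds along the chain from a sulfonamide nitrogen. Within the data shown here, no measured pair shows a step of this kind, so in this assay a change within the scatter is expected, in neither direction. Compound 3 is estimated at 6000 nM (range 2500 nM to 15000 nM). The expected step is a step that the limit leaves unreadable from compound 2 to compound 3, most likely reported again only as a limit.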

Compound 3, half-maximal inhibitory concentration: 910 nM
Compound 3: middle estimate off by 6.6-fold (0.82 log units), on the high side; the measured number lies below the stated range.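

In this assay, the saturated chain carrying the acid responds to a small extension: carboxymethyl in place of carboxy on a saturated chain carbon, four bonds along the chain from a sulfonamide nitrogen, gives an at least 3.5-fold lower number from compound 2 to compound 3 (0.54 log units; beyond the scatter). Compound 3 is the only compound shown whose value is not a limit, so this position is the first in the series to give a readable number.

From the compounds shown here alone, the full size of the step stays open because compound 2 is read only as a limit: the limit of > 3200 nM in this assay, at which 2 of the 3 values shown sit. Whether a longer chain ending in the carboxylic acid, or a primary amide in place of that acid, lowers the number further also stays open.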